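The compounds below may be only part of what the source reports. "The series", "measured", "known", "first", "only" and "open" are said of these compounds alone.

Measured compounds:
compound 1 `Cc1c(OCCCCOc2ccc(C(=O)O)cc2F)ccc(C(=O)CC2CCCC2)c1O` — in an assay on HEK293 cells for positive allosteric modulation of metabotropic glutamate receptor 3 (Rattus norvegicus), read by thallium flux, with a stated time of 2.5 min (on this read-out lower numbers stand for an effect already at smaller amounts and higher numbers for an effect only at larger amounts of compound), compound 1 gives > 10000 nM
compound 2 `Cc1c(OCCCCOc2ccc(C(=O)O)cc2F)ccc(C(=O)CC(C)C)c1O` — compound 2 gives 1420 nM
compound 3 `CCCC(=O)c1ccc(OCCCCOc2ccc(C(=O)O)cc2C)c(C)c1O` — compound 3 gives > 10000 nM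

The value of compound 1 is a limit of this assay, not a number. The value of compound 3 is likewise a limit. For the measured compounds named here, the one measured step, an at least 7.0-fold lower number from compound 1 to compound 2 (0.84 log units; beyond the scatter), concerns the group on the saturated chain carbon bound to the carbonyl carbon, which compound 4 `Cc1ccc(C(=O)O)cc1OCCCCOc1ccc(C(=O)CC2CCCC2)c(O)c1C` keeps unchanged. Compound 4 differs from compound 1 by 5-carboxy-2-methylphenyl in place of 4-carboxy-2-fluorophenyl on an oxygen on a saturated carbon. Going by the values given here, no measured step bears on this change, so no direction can be drawn from the data. Compound 4 is therefore expected to stay near the limit, estimated at 15000 nM (range 5000 nM to 50000 nM), which would mean an expected step that the limit leaves unreadable from compound 1 to compound 4.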

Compound 4, half-maximal effective concentration: > 10000 nM
Compound 4 ended at the assay's limit; the forecaster's own chance of this, stated with the estimate: 70%; the middle value does not contradict the limit.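

For the compounds shown here, compound 4, like compound 1, ends at a limit and not at a number, so no step between them can be read: the limit of > 10000 nM in this assay, at which 3 of the 4 values shown sit. The compounds shown leave open whether 5-carboxy-2-methylphenyl in place of 4-carboxy-2-fluorophenyl changes the effect at all.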